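Chloro Substitution Across Two Hydroxamic Acid Cores

A few compounds are considered here, and "the series" means these few. Any claim that something is new, unique, unknown or untested is made for them only; others in the source may bear on it.

Compound 1 `O=C(CCCCCCN1C(=O)/C(=N\O)c2ccccc21)NO` is assessed in a functional assay on PC-3 cells (Homo sapiens) for antiproliferative activity, read by sulforhodamine B assay, with a stated time of 48 h (a lower number here means a stronger inhibitor, a higher number a weaker inhibitor), where compound 1 gives 980 nM. Compound 2 `O=C(CCCCCCN1C(=O)/C(=N\O)c2cc(Cl)ccc21)NO` differs from it by chloro in place of hydrogen on an aromatic carbon, and in this assay compound 2 gives 850 nM; the step is a 1.2-fold lower number from compound 1 to compound 2 (0.06 log units; within the scatter). Compound 3 `CO/N=C1/C(=O)N(CCCCCCC(=O)NO)c2ccccc21` is built on a second core; the difference between the two cores is not broken down here. In this assay compound 3 gives 1670 nM. The numbers of compound 1, compound 2 and compound 3 all lie within the scatter of one another, so no order among them is claimed.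

Compound 4 `CO/N=C1/C(=O)N(CCCCCCC(=O)NO)c2c(Cl)cccc21` has not yet been measured in this assay. It is related to compound 3 by chloro in place of hydrogen on an aromatic carbon. Among the compounds with values here, this is the same kind of change as the one from compound 1 to compound 2, though not the same: in compound 2 the chloro stands meta to a fused ring and para to a fused ring, whereas in compound 4 it stands ortho to a fused ring and meta to a fused ring. Within the data shown here, only one example of this kind of change is at hand, and it stayed within the scatter. It is therefore expected that the step will be a 1.2-fold lower number from compound 3 to compound 4 (0.08 log units; within the scatter), because the earlier step of the same kind was a 1.2-fold lower number from compound 1 to compound 2 (0.06 log units; within the scatter). On that basis compound 4 is estimated to give 1400 nM in this assay, with a range from 600 nM to 3500 nM.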

Compound 4, half-maximal inhibitory concentration: 290 nM
Compound 4: middle estimate off by 4.8-fold (0.68 log units), on the high side; measured number below the stated range.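

In this assay, chloro in place of hydrogen on an aromatic carbon gives a 5.8-fold lower number from compound 3 to compound 4 (0.76 log units; beyond the scatter), and the same change does not have the same size on the two cores: the same change on two cores in this assay, a 1.2-fold lower number (0.06 log units; within the scatter) from compound 1 to compound 2 and a 5.8-fold lower number (0.76 log units; beyond the scatter) from compound 3 to compound 4, 5.0-fold (0.70 log units) apart, beyond the scatter of two such steps. The size of this change therefore cannot simply be carried from the core of compound 1 to the core of compound 3 in this series, even though the direction of the number is the same in the two printed steps. What this does not show is the source of the gap, as the two steps differ both in the core and in where the chloro stands, meta to a fused ring and para to a fused ring in compound 2 but ortho to a fused ring and meta to a fused ring in compound 4, and a single step on each core cannot separate the two.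

The compounds shown leave open whether chloro at the place it holds in compound 4 would give a step of similar size on the core of compound 1, and whether chloro at the place it holds in compound 2 would do so on the core of compound 3. They also leave open whether fluoro, bromo or methoxy at the place of the chloro in compound 4, or a longer chain on the same core, would keep the lower number seen for compound 4.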